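Cytotoxicity notes: nitrophenyl analogue and its ring epimer

The compounds below may be only part of what the source reports. "The series", "measured", "known", "first", "only" and "open" are said of these compounds alone.

Measured in an ADME assay on HepG2 2.2.15 cells (Homo sapiens) for cytotoxicity, read by neutral red uptake (a higher number here means that more compound is tolerated, a lower number that less compound is tolerated), so far:
- compound 1 `O=c1n([C@H]2CO[C@H](CO)O2)cc(F)c2nc(CO)cn12`: 1390000 nM
- compound 2 `O=c1n([C@H]2CO[C@H](CO)O2)ccc2nc(-c3ccc([N+](=O)[O-])cc3)cn12`: 517000 nM

Compound 2 gives the lowest of the two numbers in this assay; the nearest is compound 1, whose number is higher by a gap beyond the scatter, so compound 2 is the less tolerated of the two. Among the compounds with values here, no pair of measured compounds differs in one place, so no step size is known from these data.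

Compound 3 `O=c1n([C@H]2CO[C@@H](CO)O2)ccc2nc(-c3ccc([N+](=O)[O-])cc3)cn12` is the next compound for this assay. Its relation to compound 2 is the two compounds have the same atoms and bonds and differ only in configuration as drawn: 1 of 2 stereo elements differ; a stereocentre at a saturated ring carbon is drawn S in compound 2 and R in compound 3. Nothing measured here shows what a change of configuration alone does in this assay. The expectation is a step from compound 2 of a 1.0-fold lower number from compound 2 to compound 3 (0.01 log units; within the scatter), that is none beyond the scatter. Compound 3 is therefore estimated at 500000 nM, with a range from 200000 nM to 1300000 nM.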

Compound 3, half-maximal cytotoxic concentration: 486000 nM
The estimate for compound 3 lay 1.0-fold (0.01 log units) above the measured number; measured number inside the range.
By their numbers in this assay, from the lowest: compounds 3 and 2 (each within the scatter of the next); then compound 1.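

Within the data shown here, the first single-place step comes from the stereocentre at the saturated ring carbon: in this assay, a 1.1-fold lower number from compound 2 to compound 3 (0.03 log units; within the scatter), which lies within the scatter. Among these compounds, for this nitrophenyl pair, the configuration drawn at that carbon therefore does not separate the two compounds, a point the earlier compounds could not show. The step can be read as a pure effect of configuration because nothing else changes: the fact that compounds 2 and 3 differ only in the configuration as drawn

As far as these compounds go, this holds for one stereocentre on one substituent pattern, and whether it carries over to the fluoro, hydroxymethyl pattern of compound 1 remains open. Also open, from the compounds shown here alone, is how this assay responds when a single group changes on the shared core, for example an amine or a carboxylic acid in place of the nitro group on the phenyl ring.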